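Adding a Phenyl Ring Next to the Nitro-Bearing Aryl

The compounds below may be only part of what the source reports. "The series", "measured", "known", "first", "only" and "open" are said of these compounds alone.

Measured compounds:
compound 1 `O=[N+]([O-])c1ccc(-c2cc(-c3ccccc3)n[nH]2)cc1` — 10200 nM
compound 2 `COc1ccc(-c2cc(-c3ccc([N+](=O)[O-])cc3)[nH]n2)cc1` — 18300 nM
compound 3 `COc1ccc(-c2cc(-c3ccccc3)n[nH]2)cc1` — 10400 nM

In a functional assay on NCI-H460 cells (Homo sapiens) for inhibition, read by MTT assay, with a stated time of 48 h (a lower number here means a stronger inhibitor of growth, a higher number a weaker inhibitor of growth), compound 1 gives 10200 nM, the lowest of the three numbers, though its neighbours sit close: compound 3 differs from it by a 1.0-fold higher number from compound 1 to compound 3 (0.01 log units; within the scatter), and compound 2 by a 1.8-fold higher number from compound 1 to compound 2 (0.25 log units; within the scatter). Both of those steps stay inside the usual scatter, so the three compounds cannot be told apart by potency on this evidence.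

Compound 4 `O=[N+]([O-])c1ccc(-c2cc(-c3ccccc3-c3ccccc3)n[nH]2)cc1` is not yet measured. It differs from compound 1 by phenyl in place of hydrogen on an aromatic carbon; the phenyl enters on an aromatic carbon of a six-membered aromatic ring of carbon only, ortho to a large group.

Neither measured step matches this change. Both involve a methoxy on an aromatic carbon, and both left the number where it was. That offers no direct guide for a phenyl, only a hint that this scaffold has so far tolerated changes on its aryl rings without a shift beyond the scatter.

On that basis compound 4 is expected to land close to compound 1, with a step of a 1.2-fold higher number from compound 1 to compound 4 (0.07 log units; within the scatter), and an estimate of 12000 nM spanning 4000 nM to 36000 nM.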

Compound 4, concentration for 50% growth inhibition: 2700 nM
The estimate for compound 4 lay 4.4-fold (0.65 log units) above the measured number; measured number outside the range, below it.
By their numbers in this assay, from the lowest: compound 4; then compounds 1, 3 and 2 (each within the scatter of the next).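

In this assay, phenyl in place of hydrogen gives a 3.8-fold lower number from compound 1 to compound 4 (0.58 log units; beyond the scatter) and so produces the only step shown here that goes beyond the scatter, though it is modest in size. The earlier steps shown here, a 1.8-fold higher number from compound 1 to compound 2 (0.25 log units; within the scatter) and a 1.0-fold higher number from compound 1 to compound 3 (0.01 log units; within the scatter), both stayed within the scatter and so gave no sign of a place on these molecules where a change moves the number. This aromatic carbon, ortho to a large group, is now such a place, and a substituent of 6 heavy atoms there goes with stronger growth inhibition than hydrogen, although no measurement at hand explains the shift.

The compounds shown leave open whether the effect needs a whole aromatic ring or whether a smaller group at the same carbon, such as a methyl, a chlorine or an amine, would lower the number as well. They also leave open whether phenyl on other carbons of that ring would do the same, and whether the gain would persist with methoxy in place of nitro on the other aryl ring.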